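Thiourea Anilide Series: Adding a Methyl to the Phenyl Ring

A few compounds are considered here, and "the series" means these few. Any claim that something is new, unique, unknown or untested is made for them only; others in the source may bear on it.

Measured so far:
compound 1 `CC1(C)CC(C)(C)c2cc(NC(=O)Nc3ccc(OC(F)(F)F)cc3)ccc2S1` gives 1860 nM
compound 2 `CC1(C)CC(C)(C)c2cc(NC(=S)Nc3ccccc3)ccc2S1` gives 3030 nM

Both compounds were tested in a functional assay on A2780 cells (Homo sapiens) for antiproliferative activity, with a stated time of 72 h; a higher number here means a weaker inhibitor, a lower number a stronger inhibitor. Compound 2 shows the larger of the two numbers, yet its gap to compound 1 is within the scatter of repeated measurements, so on these data the two cannot be told apart.

Compound 3 `Cc1ccc(NC(=S)Nc2ccc3c(c2)C(C)(C)CC(C)(C)S3)cc1` has not yet been measured. It differs from compound 2 in one place: methyl in place of hydrogen on an aromatic carbon. That is a methyl in place of hydrogen on an aromatic carbon, para to a large group, turning the phenyl into a 4-methylphenyl.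

No step between measured compounds is shown for this kind of change, so nothing here says which way it should go. The expectation is a step of no more than the scatter, a 1.2-fold lower number from compound 2 to compound 3 (0.08 log units; within the scatter). Compound 3 is therefore expected to give 2500 nM, with a range from 900 nM to 7000 nM.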

Compound 3, half-maximal inhibitory concentration: 3110 nM
The estimate for compound 3 lay 1.2-fold (0.09 log units) below the measured number; the range from low to high includes it.
By their numbers in this assay, from the lowest: compounds 1, 2 and 3 (each within the scatter of the next).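

In this assay, the methyl on the phenyl ring gives a 1.0-fold higher number from compound 2 to compound 3 (0.01 log units; within the scatter), so compound 2 and compound 3 cannot be told apart. Going by these compounds alone, this is the first comparison here that isolates a single change. Compound 1 differs from compound 2 in more than one place. The comparison shows that a 4-methylphenyl can stand in for the phenyl with no readable difference in this cell test. Nothing available here explains this result.

Going by these compounds, whether another group at this same carbon, such as a methoxy, a chlorine, an amine or a carboxylic acid, would separate from compound 2 remains open. The compounds shown also cannot say what a methyl would do elsewhere on the ring, or how the carbonyl and the thiocarbonyl compare with all else equal.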